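An Ethyl Group on the Ring Amide Nitrogen

This account rests on a few compounds, and the source may have more. Where it says the series, first, only, none or still open, it means among the compounds named here.

Three compounds share one core and differ at one aromatic carbon. Compound 1 `CN1CCN(c2ccc(Nc3ncc4c(n3)N(C3CCCC3)CC(=O)N4)cc2)CC1` carries a 4-methylpiperazin-1-yl group there, compound 2 `O=C1CN(C2CCCC2)c2nc(Nc3ccc(N4CCCCC4)cc3)ncc2N1` carries piperidin-1-yl, and compound 3 `CC1CCN(c2ccc(Nc3ncc4c(n3)N(C3CCCC3)CC(=O)N4)cc2)CC1` differs again only on that aromatic carbon. In an ADME assay on HEK293 cells (Homo sapiens) for inhibition, read by MTT assay, with a stated time of 48 h (on this read-out higher numbers stand for weaker inhibition and lower numbers for stronger inhibition), compound 1 gives only a limit of the assay, > 30000 nM. In this assay, within the data shown here, compound 2 gives 25100 nM, the one plain number of the three. For compound 3 the result in this assay is "not determined" (no result reported). Among the measured compounds shown here, compound 2 thus stands as the only compound with a measured number, one companion sitting at the limit and one without a result. For the measured compounds named here, the single measured step, an at least 1.1-fold lower number from compound 1 to compound 2 (0.07 log units; that floor lies within the scatter), concerns the aromatic substituent and starts from a limit, (the limit of > 30000 nM in this assay, at which 1 of the 3 values shown sits).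

Compound 4 `CCN1C(=O)CN(C2CCCC2)c2nc(Nc3ccc(N4CCCCC4)cc3)ncc21` differs from compound 2 in one place: ethyl in place of hydrogen on an amide-type nitrogen in a ring. No measured step touches this amide nitrogen, so the change from compound 2 to compound 4 has no precedent among these compounds. The step of a 1.3-fold lower number from compound 2 to compound 4 (0.10 log units; within the scatter) is therefore expected to stay within the scatter. Compound 4 is estimated at 20000 nM in this assay, with a range from 7000 nM to 60000 nM.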

Compound 4, half-maximal inhibitory concentration: > 30000 nM
Compound 4: a limit, no number; the forecaster's own chance of this, stated with the estimate: 30%; at least 1.5-fold (0.17 log units) between middle value and limit.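

In this assay compound 4 gives > 30000 nM, which is a limit of the assay and not a number. Among these compounds, this is the first look at the amide nitrogen in these compounds, and putting ethyl there in place of the amide hydrogen gives an at least 1.1-fold higher number from compound 2 to compound 4 (0.07 log units; that floor lies within the scatter), a floor rather than a full size, so the real step may be larger or may be no more than scatter. What the result does show is that ethyl on this nitrogen brings no sign of stronger inhibition, and compound 4 joins compound 1 at the top of the range that can be read: the limit of > 30000 nM in this assay, at which 2 of the 4 values shown sit.

Going by these compounds, how a methyl group, or a longer chain ending in an amine or a carboxylic acid, would read on this nitrogen stays open. Also open, on these data alone, is how large the step from the amide hydrogen to ethyl really is, since only a limit stands on one side of it.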